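A few compounds are considered here, and "the series" means these few. Any claim that something is new, unique, unknown or untested is made for them only; others in the source may bear on it.

Measured in a functional assay on HeLa cells (Homo sapiens) for inhibition, read by CCK-8 assay, with a stated time of 72 h; a lower number here means a stronger inhibitor, a higher number a weaker inhibitor:
- compound 1 `Cc1ccccc1NS(=O)(=O)c1cccc(CCCCCCNC(=O)/C=C/c2cccnc2)c1`: 2.34 nM
- compound 2 `Cc1ccc(C)c(NS(=O)(=O)c2cccc(CCCCCCNC(=O)/C=C/c3cccnc3)c2)c1`: 22.6 nM
- compound 3 `CC(C)(C)c1ccc(NS(=O)(=O)c2cccc(CCCCCCNC(=O)/C=C/c3cccnc3)c2)cc1`: 1520 nM

Among these three, compound 3 is the weakest inhibitor, at 1520 nM. The gaps to the other two are wide: a 67-fold higher number from compound 2 to compound 3 (1.83 log units; beyond the scatter) and a 650-fold higher number from compound 1 to compound 3 (2.81 log units; beyond the scatter). Compound 4 `O=C(/C=C/c1cccnc1)NCCCCCCc1cccc(S(=O)(=O)Nc2ccc(F)cc2)c1` has not yet been measured. It carries fluoro in place of tert-butyl on an aromatic carbon.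

Two of the measured steps bear most directly on this change. Each replaces the group on the sulfonamide nitrogen with 4-(tert-butyl)phenyl, and each is large: a 650-fold higher number from compound 1 to compound 3 (2.81 log units; beyond the scatter) and a 67-fold higher number from compound 2 to compound 3 (1.83 log units; beyond the scatter). A smaller edit can also matter, since adding one methyl gives a 9.7-fold higher number from compound 1 to compound 2 (0.98 log units; beyond the scatter). For the measured compounds named here, no measured compound carries fluoro, so the data cannot show directly how this group behaves. Still, every measured compound without tert-butyl lies far below compound 3, so removing that group is expected to give a large step to a lower number. The fluoro compound need not match compound 1, however, so the expected range stays wide.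

The estimated step is a 38-fold lower number from compound 3 to compound 4 (1.58 log units; beyond the scatter). For compound 4, the expected value is 40 nM, with an estimated range of 5 nM to 300 nM.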

Compound 4, half-maximal inhibitory concentration: 99.9 nM
Beside the measured number, compound 4's estimate is 2.5-fold (0.40 log units) below it, and the stated range covers the measured number.
By their numbers in this assay, from the lowest: compound 1; then compound 2; then compound 4; then compound 3.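

In this assay, fluoro in place of tert-butyl on the same aromatic carbon gives a 15-fold lower number from compound 3 to compound 4 (1.18 log units; beyond the scatter), so the group at this one carbon strongly affects the number, even with the rest of the molecule unchanged. Removing tert-butyl does not by itself recover the lowest numbers, however: 4-fluorophenyl in place of 2-methylphenyl gives a 43-fold higher number from compound 1 to compound 4 (1.63 log units; beyond the scatter), and in place of 2,5-dimethylphenyl it gives a 4.4-fold higher number from compound 2 to compound 4 (0.65 log units; beyond the scatter). Among these four compounds, then, both methyl-bearing rings on the sulfonamide nitrogen give lower numbers than either ring carrying a single group at this carbon, and compound 4 sits between compound 2 and compound 3.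

The compounds shown offer no measurement that explains these steps. As far as these compounds go, it also stays open whether chloro, methoxy or an amine at this same carbon would give a number closer to compound 4 or to compound 3, and whether a plain phenyl ring with no added group would approach compound 1.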